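The compounds below may be only part of what the source reports. "The series", "measured", "known", "first", "only" and "open" are said of these compounds alone.

Compound 1 `CCCCCCCCOC1CC(=O)Nc2c1c(C)nn2-c1ncnc2nc[nH]c12` gives 388 nM in a functional assay on HEK293 cells for agonist activity at G-protein coupled receptor 39 (Homo sapiens), read by scintillation proximity assay and inositol phosphate accumulation, with a stated time of 75 min (a lower number here means that less compound is needed, a higher number that more compound is needed for the effect), the lowest of the two numbers measured. Compound 2 `Cc1nn(-c2ncnc3nc[nH]c23)c2c1C(OCCn1nccc1C)CC(=O)N2` gives 1620 nM in this assay, and the step of a 4.2-fold higher number from compound 1 to compound 2 (0.62 log units; beyond the scatter) shows that trading chain for a ring here cost potency. Compound 3 `Cc1nn(-c2ncnc3nc[nH]c23)c2c1C(OCc1ccccc1Cl)CC(=O)N2` differs from compound 1 by 2-chlorophenyl in place of heptyl on a saturated chain carbon bound to an oxygen on a saturated carbon. Going by the values given here, that earlier step is the only one bearing on this change, and it points to a modest loss. For compound 3 a step of a 2.3-fold higher number from compound 1 to compound 3 (0.37 log units; beyond the scatter) is therefore expected, so compound 3 is estimated at 900 nM, within a range of 300 nM to 2700 nM.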

Compound 3, half-maximal effective concentration: 47 nM
For compound 3 the middle estimate is 19-fold (1.28 log units) above the measured one, and the stated range ends above it.
By their numbers in this assay, from the lowest: compound 3; then compound 1; then compound 2.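

At this position a ring can do better than a long chain: 2-chlorobenzyl in place of octyl gives an 8.3-fold lower number from compound 1 to compound 3 (0.92 log units; beyond the scatter). The kind of ring also matters, as swapping the pyrazole-bearing side chain for 2-chlorobenzyl gives a 34-fold lower number from compound 2 to compound 3 (1.54 log units; beyond the scatter), so the loss seen with compound 2 does not extend to every ring. No evidence here explains this difference. The compounds shown leave open whether the chlorine contributes to the result. A plain benzyl group, or a benzyl group carrying an amine instead of chlorine, would address this.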